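This account rests on a few compounds, and the source may have more. Where it says the series, first, only, none or still open, it means among the compounds named here.

Compound 1 `Cc1ccc(N2CCN(c3ccc(C(=O)/C=C/c4ccccc4)cc3)CC2)c(C)c1` gives 15% in a functional assay on the whole organism (strain Kunming) for inhibition, with Mus musculus as the target, with a stated time of 1 h, at a dose of 40 mg/kg by the oral route; on this read-out lower numbers stand for less inhibition and higher numbers for more inhibition at the one dose given (going by the name of the read-out). Within the data shown here, compound 2 `COc1ccc(/C=C/C(=O)c2ccc(N3CCN(c4ccc(C)cc4C)CC3)cc2)cc1OC` gives 48.5% in the same read-out, and the step of a number 33.5 percentage points higher from compound 1 to compound 2 (beyond the scatter) is the one change measured so far. Compound 2 therefore stands highest of the two numbers shown, with compound 1 as its only neighbour.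

Compound 3 `COc1ccc(/C=C/C(=O)c2ccc(N3CCN(S(=O)(=O)c4ccc(Br)cc4)CC3)cc2)cc1OC` carries the change ((4-bromophenyl)sulfonyl in place of 2,4-dimethylphenyl on an amine nitrogen in a ring). Among the measured compounds shown here, the single measured step concerns the group on the double-bonded chain carbon, not the amine nitrogen in the ring, so it does not bear on this change; nothing measured here speaks to swapping the 2,4-dimethylphenyl for a (4-bromophenyl)sulfonyl at that nitrogen. Given that the two compounds measured so far span a wide range in this assay, a step in either direction beyond the scatter cannot be ruled out, and the expected step of a number 13.5 percentage points lower from compound 2 to compound 3 (beyond the scatter) is set as a modest drop toward the middle of what has been seen. Compound 3 is thus estimated to give 35%, within a range of 10% to 60%.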

Compound 3, a percentage reported as inhibition, in the whole organism at one dose (the size of the read-out at that dose, not a potency): 75.5%
Beside the measured number, compound 3's estimate is 40.5 percentage points below it, outside the stated range (above it).
By their numbers in this assay, from the lowest: compound 1; then compound 2; then compound 3.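

Among these compounds, the earlier step concerned only the group on the double-bonded chain carbon, so this is the first reading of a change on the amine nitrogen in the ring. In this assay, placing (4-bromophenyl)sulfonyl there instead of 2,4-dimethylphenyl gives a number 27 percentage points higher from compound 2 to compound 3 (beyond the scatter), which shows that the number still responds to this nitrogen's substituent with the 3,4-dimethoxyphenyl end held constant. The entering group keeps one six-membered aromatic ring of carbon only, but it adds the sulfur, the bromine and the 2 hydrogen-bond acceptors, and no measurement says why the number rises.

The compounds shown leave open which part of the (4-bromophenyl)sulfonyl group goes with the higher number, since the sulfonyl and the bromine enter together; a plain phenylsulfonyl, a 4-bromobenzoyl or a methylsulfonyl group on the same nitrogen would begin to separate them. They also leave open whether the step would recur with phenyl rather than 3,4-dimethoxyphenyl on the double-bonded chain carbon, and whether it would persist at other doses or times.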